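The source may hold more compounds than are shown below. What is called first, only, known or untested is meant among the compounds shown, and "the series" means these compounds.

Measured compounds: compound 1 `COC(=O)c1nc(C)n(-c2ccc(F)cc2)n1` gives 8700 nM in a functional assay on Jurkat cells (Homo sapiens) for inhibition, read by MTT assay, with a stated time of 72 h; a higher number here means a weaker inhibitor of growth, a lower number a stronger inhibitor of growth; compound 2 `COC(=O)c1nc(C2CCCC2)n(-c2ccc(F)cc2)n1` gives 9550 nM in this assay.

Among the compounds with values here, compound 2 carries the higher of the two numbers, yet the only measured step, a 1.1-fold higher number from compound 1 to compound 2 (0.04 log units; within the scatter), lies within the scatter, so the two compounds cannot be ordered. Compound 3 `COC(=O)c1nc(C2CCCCC2)n(-c2ccc(F)cc2)n1` differs from compound 2 by cyclohexyl in place of cyclopentyl on an aromatic carbon. Within the data shown here, the one relevant step, cyclopentyl in place of methyl, did nothing beyond the scatter, so adding one more ring carbon is expected to leave this assay essentially unchanged, with no step beyond the scatter. Compound 3 is therefore estimated at 9500 nM, with a range from 4000 nM to 23000 nM, and the expected change is a 1.0-fold lower number from compound 2 to compound 3 (0.00 log units; within the scatter).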

Compound 3, concentration for 50% growth inhibition: > 100000 nM
Compound 3: a limit, no number (the forecaster's own chance of this, stated with the estimate: 5%); middle value at least 10-fold (1.02 log units) away from the limit.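

In this assay compound 3 gives a limit, not a number: the limit of > 100000 nM in this assay, at which 1 of the 3 values shown sits.

This position therefore tolerates some changes but not others. Methyl and cyclopentyl cannot be ordered, yet one more ring carbon gives an at least 10-fold higher number from compound 2 to compound 3 (1.01 log units; beyond the scatter), and the step from methyl gives an at least 11-fold higher number from compound 1 to compound 3 (1.06 log units; beyond the scatter).

As far as these compounds go, the true size of both steps stays unknown, since one end of each is a limit. From the compounds shown here alone, whether a phenyl ring, an open chain such as isopropyl, or an amine at this position would stay close to compound 2 or fall off like compound 3 remains open.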